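From 2-bromophenyl to 3-bromophenyl

The source may hold more compounds than are shown below. What is called first, only, known or untested is meant among the compounds shown, and "the series" means these compounds.

In a functional assay on HepG2 cells (Homo sapiens) for antiproliferative activity, read by MTT assay, with a stated time of 72 h (on this read-out higher numbers stand for weaker inhibition and lower numbers for stronger inhibition), compound 1 `NC1=NC2(CCSCC2)N(OCCCOc2cccc(Cl)c2)C(N)=N1` gives 90 nM and compound 2 `NC1=NC2(CCSCC2)N(OCCCOc2ccccc2Br)C(N)=N1` gives 90 nM, so compound 2 stands level with compound 1. Compound 3 `NC1=NC2(CCSCC2)N(OCCCOc2cccc(Br)c2)C(N)=N1` is not yet measured and differs from compound 2 by one change: 3-bromophenyl in place of 2-bromophenyl on an oxygen on a saturated carbon. Here 3-bromophenyl sits in place of 2-bromophenyl on an oxygen on a saturated carbon. Within the data shown here, the only measured step that bears on this swap at the same place is no change at the digits printed from compound 1 to compound 2 (within the scatter). In this assay the expected step is therefore no change at the digits printed from compound 2 to compound 3 (within the scatter), none beyond the scatter. Compound 3 is estimated at 90 nM, with an expected range from 40 nM to 200 nM.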

Compound 3, half-maximal inhibitory concentration: 90 nM
For compound 3 middle estimate and measured number coincide at the digits printed, within the range that was stated.
By their numbers in this assay, from the lowest: compounds 1, 2 and 3 (each within the scatter of the next).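

In this assay the swap of 3-bromophenyl for 2-bromophenyl on an oxygen on a saturated carbon gives no change at the digits printed from compound 2 to compound 3 (within the scatter) and bromo in place of chloro on an aromatic carbon gives no change at the digits printed from compound 1 to compound 3 (within the scatter) as a separate change. The earlier step changed the halogen and its ring position together, whereas these two steps show each change alone leaving the number level. Nothing available explains this flat result. Still open, on these data alone, is whether an amine or a carboxylic acid in place of the halogen, or a longer chain, would leave the number level too.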